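Replacing the Aromatic Group of Compound 3

The compounds below may be only part of what the source reports. "The series", "measured", "known", "first", "only" and "open" are said of these compounds alone.

Compound 1 `CCCS(=O)(=O)N1CCC(CNC(=O)c2ccc(F)cc2C(F)(F)F)(C(=O)N2CCOCC2)CC1` gives 0.3 h
Compound 2 `CCCS(=O)(=O)N1CCC(CNC(=O)c2c(F)cccc2F)(C(=O)N2CCOCC2)CC1` gives 0.3 h
Compound 3 `CCCS(=O)(=O)N1CCC(CNC(=O)c2c(F)ccc(Cl)c2F)(C(=O)N2CCOCC2)CC1` gives 0.3 h

These results all come from an ADME assay on the whole organism for metabolic stability, with Rattus norvegicus as the target; on this read-out lower numbers stand for a shorter-lived compound and higher numbers for a longer-lived compound. Compound 1 and compound 2 sit level with compound 3 at 0.3 h, so none of the three stands out on the numbers available.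

The next compound, compound 4 `CCCS(=O)(=O)N1CCC(CNC(=O)c2ccccc2Cl)(C(=O)N2CCOCC2)CC1`, keeps the shared core and differs only in the aromatic group on the carbonyl carbon: 2-chlorophenyl in place of 3-chloro-2,6-difluorophenyl on a carbonyl carbon. In words, 2-chlorophenyl takes the place of 3-chloro-2,6-difluorophenyl.

Going by the values given here, three measured steps bear on this change. Exchanging one substituted phenyl group for another at this same carbonyl gave no change at the digits printed from compound 1 to compound 2 (within the scatter) and also no change at the digits printed from compound 1 to compound 3 (within the scatter). Adding a single chloro to an aromatic carbon gave no change at the digits printed from compound 2 to compound 3 (within the scatter). Each of these steps is no larger than the ordinary spread between repeat measurements.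

Among the compounds with values here, none of the measured compounds carries the 2-chlorophenyl group, so the comparison is indirect and no direction can be favoured. No step beyond the scatter is expected in this assay. The expected step is no change at the digits printed from compound 3 to compound 4 (within the scatter). Compound 4 is estimated at 0.3 h, with an expected range of 0.2 h to 0.6 h.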

Compound 4, half-life: 0.3 h
Beside the measured number, compound 4's estimate shows no gap at the digits printed, within the range that was stated.
By their numbers in this assay, from the lowest: compounds 1, 2, 3 and 4 (each within the scatter of the next).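

The 2-chlorophenyl group is the only one of the four on this carbonyl carbon that carries no fluorine, yet in this assay the swap gives no change at the digits printed from compound 3 to compound 4 (within the scatter). Set against the other two groups, it gives no change at the digits printed from compound 2 to compound 4 (within the scatter), and likewise no change at the digits printed from compound 1 to compound 4 (within the scatter). Four differently substituted phenyl groups therefore sit level at this position, with or without fluorine, though nothing measured here explains why the read-out holds steady.

Going by these compounds, all four groups are halogen-bearing phenyl rings, so it remains open whether a phenyl carrying an amine or a carboxylic acid, or a saturated cyclohexyl group in place of the phenyl, would also stay level in this assay. The shared core is the same in all four compounds, so these results also leave open whether a change there, such as a longer chain in place of the propyl on the sulfonyl group, would move this number.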